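The compounds below may be only part of what the source reports. "The series", "measured", "known", "first", "only" and "open" are said of these compounds alone.

Measured so far in a functional assay on SW-620 cells (Homo sapiens) for cytotoxicity, read by MTT assay, with a stated time of 72 h; a lower number here means a stronger inhibitor, a higher number a weaker inhibitor:

Compound 1 `COc1ccc(/C=C2\CCC/C(=C\c3cccc(OC)c3OC)C2=O)cc1`: 13600 nM.
Compound 2 `COc1cccc(/C=C2\CCC/C(=C\c3ccc(O)cc3)C2=O)c1OC`: > 20000 nM, which is a limit of the assay.
Compound 3 `COc1cccc(/C=C2\CCC/C(=C\c3ccc(Cl)cc3Cl)C2=O)c1OC`: 16300 nM.

Going by the values given here, only two of these values are numbers, and they do not separate: the measured change is a 1.2-fold higher number from compound 1 to compound 3 (0.08 log units; within the scatter). Compound 3 therefore stands with compound 1, within the scatter of it.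

The next compound is compound 4 `COc1cccc(/C=C2\CCC/C(=C\c3ccc(O)c(O)c3)C2=O)c1OC`. It keeps the shared core and carries 3,4-dihydroxyphenyl in place of 2,4-dichlorophenyl on a double-bonded chain carbon bound to a double-bonded ring carbon.

The closest evidence is a change at that same place, 2,4-dichlorophenyl in place of 4-hydroxyphenyl, measured as an at least 1.2-fold lower number from compound 2 to compound 3 (0.08 log units; that floor lies within the scatter). It gives only a floor, and so does the loss of a methyl on an oxygen, an at least 1.4-fold higher number from compound 1 to compound 2 (0.16 log units; that floor lies within the scatter). Among the compounds with values here, no measured step lies beyond the scatter, so no step beyond the scatter is expected in this assay, although a ring bearing hydroxyl may stay out of reach of a number, as the limit for compound 2 shows.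

The expected step is a 1.4-fold lower number from compound 3 to compound 4 (0.13 log units; within the scatter). For compound 4 the estimated value is 12000 nM, with an expected range from 4000 nM to 25000 nM.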

Compound 4, half-maximal inhibitory concentration: 6300 nM
Estimate against measurement, compound 4: 1.9-fold (0.28 log units) above; the measured number falls inside the stated range.
By their numbers in this assay, from the lowest: compound 4; then compounds 1 and 3 (each within the scatter of the next). At a limit, above all of these: compound 2.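

In this assay, the place on a double-bonded chain carbon bound to a double-bonded ring carbon now gives steps beyond the scatter, which no earlier pair had shown: 3,4-dihydroxyphenyl in place of 2,4-dichlorophenyl gives a 2.6-fold lower number from compound 3 to compound 4 (0.41 log units; beyond the scatter), and in place of 4-methoxyphenyl it gives a 2.2-fold lower number from compound 1 to compound 4 (0.33 log units; beyond the scatter). Hydroxy in place of hydrogen on an aromatic carbon of the 4-hydroxyphenyl ring gives an at least 3.1-fold lower number from compound 2 to compound 4 (0.50 log units; beyond the scatter), so among these compounds a ring bearing hydroxy is not tied to weak inhibition, with compound 4 and compound 2 standing on opposite sides of that reading. The size of this last step is only a floor, because compound 2 stands at a limit of the assay rather than at a number: the limit of > 20000 nM in this assay, at which 1 of the 4 values shown sits.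

From the compounds shown here alone, what remains open is whether the lower number in compound 4 depends on the 3,4-dihydroxyphenyl arrangement itself, or would also appear with an amine or a carboxylic acid on the ring at that place. The compounds shown also leave open how far the step depends on the methoxy-bearing ring that all four compounds keep, and whether it would persist if a methoxy there gave way to a fluorine or an ethoxy group.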